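A Methyl Moved Around the Phenyl Ring

The source may report more compounds than this note shows. Statements on the series, on what has been measured and on what is new or still open speak of the compounds shown alone.

Measured compounds in a functional assay on SGC-7901 cells (Homo sapiens) for antiproliferative activity, read by MTT assay, with a stated time of 24 h; a higher number here means a weaker inhibitor, a lower number a stronger inhibitor:
compound 1 `O=c1[nH]cc(S(=O)(=O)Nc2ccccc2-c2cn(-c3ccccc3)nn2)c(=O)[nH]1`: 11800 nM
compound 2 `Cc1ccccc1-n1cc(-c2ccccc2NS(=O)(=O)c2c[nH]c(=O)[nH]c2=O)nn1`: 9570 nM

Compound 1 stands at the highest of the two numbers shown; the only comparison available is a 1.2-fold lower number from compound 1 to compound 2 (0.09 log units; within the scatter), which lies within the scatter. Compound 3 `Cc1cccc(-n2cc(-c3ccccc3NS(=O)(=O)c3c[nH]c(=O)[nH]c3=O)nn2)c1` differs from compound 1 by methyl in place of hydrogen on an aromatic carbon. Among the measured compounds shown here, the one step that bears on this change, also a methyl in place of hydrogen on an aromatic carbon, was a 1.2-fold lower number from compound 1 to compound 2 (0.09 log units; within the scatter), so no movement beyond the scatter is expected here. Compound 3 is therefore estimated at 10500 nM, between 5000 nM and 22000 nM, an expected step of a 1.1-fold lower number from compound 1 to compound 3 (0.05 log units; within the scatter).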

Compound 3, half-maximal inhibitory concentration: 3510 nM
The estimate for compound 3 lay 3.0-fold (0.48 log units) above the measured number, and the stated range ends above it.
By their numbers in this assay, from the lowest: compound 3; then compounds 2 and 1 (each within the scatter of the next).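

In this assay the methyl now makes a difference: as 3-methylphenyl, with the methyl meta to a large group, it gives a 3.4-fold lower number from compound 1 to compound 3 (0.53 log units; beyond the scatter) and is no longer lost in the scatter. Shifting the methyl from 2-methylphenyl to 3-methylphenyl gives a 2.7-fold lower number from compound 2 to compound 3 (0.44 log units; beyond the scatter) on its own, so among these three compounds the methyl's place on the ring counts, not just its presence. Nothing available explains this difference. From the compounds shown here alone, whether the gain is specific to methyl stays open. A chlorine, a methoxy or an amine on that same carbon could behave quite differently.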